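The source may hold more compounds than are shown below. What is called first, only, known or untested is meant among the compounds shown, and "the series" means these compounds.

Measured so far:
compound 1 `C=C(Br)C(=O)Nc1ccc(/C=C2\SC(=O)N(Cc3ccc(Cl)cc3)C2=O)cc1`, 2300 nM
compound 2 `C=C(Br)C(=O)Nc1ccc(/C=C2\SC(=O)N(Cc3ccc(F)cc3)C2=O)cc1`, 2000 nM
compound 3 `C=C(Br)C(=O)Nc1ccc(/C=C2\SC(=O)N(Cc3cccc(Cl)c3)C2=O)cc1`, 8900 nM

In a functional assay on HeLa cells (Homo sapiens) for cytotoxicity, read by cell counting, with a stated time of 4 days (on this read-out higher numbers stand for weaker inhibition and lower numbers for stronger inhibition), compound 1 gives 2300 nM and compound 2 gives 2000 nM. The change between them is fluoro in place of chloro on an aromatic carbon, and the step was a 1.2-fold lower number from compound 1 to compound 2 (0.06 log units; within the scatter). Compound 3 differs from compound 1 by 3-chlorophenyl in place of 4-chlorophenyl on a saturated chain carbon bound to an amide-type nitrogen in a ring, with a step of a 3.9-fold higher number from compound 1 to compound 3 (0.59 log units; beyond the scatter); from compound 2 the step is a 4.5-fold higher number from compound 2 to compound 3 (0.65 log units; beyond the scatter). Compound 4 `C=C(Br)C(=O)Nc1ccc(/C=C2\SC(=O)N(Cc3cccc(F)c3)C2=O)cc1` is not yet measured; it differs from compound 3 by fluoro in place of chloro on an aromatic carbon. This is the same kind of change as that from compound 1 to compound 2, but the place differs: there the halogen sits para to a large group, here meta to a large group. Because compound 1 to compound 2 showed a 1.2-fold lower number from compound 1 to compound 2 (0.06 log units; within the scatter), the step from compound 3 to compound 4 is expected to be about a 1.2-fold lower number from compound 3 to compound 4 (0.07 log units; within the scatter), within the scatter. Compound 4 is therefore estimated at 7500 nM, between 3000 nM and 20000 nM.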

Compound 4, half-maximal inhibitory concentration: 5900 nM
Estimate against measurement, compound 4: 1.3-fold (0.10 log units) above, within the range that was stated.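

In this assay, fluoro in place of chloro on an aromatic carbon gives a 1.5-fold lower number from compound 3 to compound 4 (0.18 log units; within the scatter), and the change carries over alike on the two cores: the same change on two cores in this assay, a 1.2-fold lower number (0.06 log units; within the scatter) from compound 1 to compound 2 and a 1.5-fold lower number (0.18 log units; within the scatter) from compound 3 to compound 4, 1.3-fold (0.12 log units) apart, within the scatter of two such steps. The other new steps, a 3.0-fold higher number from compound 2 to compound 4 (0.47 log units; beyond the scatter) and a 2.6-fold higher number from compound 1 to compound 4 (0.41 log units; beyond the scatter), go with 3-fluorophenyl in place of 4-fluorophenyl or 4-chlorophenyl, so among these four compounds the place of the halogen separates them, not which halogen it is. Within the data shown here, this shows only that the change stayed within the scatter in two closely related pairs; it does not show that it would do so on a more distant core.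

The compounds shown leave open whether a bromo, a methyl or a methoxy group on that aromatic ring would follow chloro and fluoro. They also leave open how an amine or a carboxylic acid there would read out.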